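Clearance after replacing difluoromethoxy in the nitrile series

This account rests on a few compounds, and the source may have more. Where it says the series, first, only, none or still open, it means among the compounds named here.

Measured so far in an ADME assay on the whole organism (Mus musculus, strain CD-1) for pharmacokinetics; a higher number here means faster removal of the compound, a lower number slower removal:
compound 1 `COc1cc([C@](O)(CCN(C)C)[C@@H](c2cc3cc(Br)ccc3nc2OC)c2ccnc(OC)c2OC)cc(OC(F)F)n1`: 8.7 mL/min/kg
compound 2 `COc1cc([C@](O)(CCN(C)C)[C@@H](c2cc3cc(C#N)ccc3nc2OC)c2ccnc(OC)c2OC)cc(OC(F)F)n1`: 24 mL/min/kg

Of the two measured compounds, compound 2 has the higher number at 24 mL/min/kg, and the gap to compound 1 lies beyond the scatter. Compound 3 `COc1cc([C@](O)(CCN(C)C)[C@@H](c2cc3cc(C#N)ccc3nc2OC)c2ccnc(OC)c2OC)cc(N(C)C)n1` keeps the nitrile of compound 2 and has dimethylamino in place of difluoromethoxy on an aromatic carbon, next to the ring nitrogen: dimethylamino in place of difluoromethoxy on an aromatic carbon. Going by the values given here, only one measured step bears on this, and only indirectly. The step of a 2.8-fold higher number from compound 1 to compound 2 (0.44 log units; beyond the scatter) is modest and concerns cyano in place of bromo, so it indicates a possible step size in this assay but not a direction. Among the compounds with values here, no measured pair tests the exchange of difluoromethoxy. With the direction open, no step beyond the scatter is expected as the central case, although a modest move either way remains possible. The expected step is a 1.1-fold lower number from compound 2 to compound 3 (0.04 log units; within the scatter). Compound 3 is estimated at 22 mL/min/kg, with an expected range of 9 mL/min/kg to 50 mL/min/kg.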

Compound 3, clearance: 26 mL/min/kg
Estimate against measurement, compound 3: 1.2-fold (0.07 log units) below; measured number inside the range.
By their numbers in this assay, from the lowest: compound 1; then compounds 2 and 3 (each within the scatter of the next).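

In this assay, the exchange of difluoromethoxy for dimethylamino on an aromatic carbon, next to the ring nitrogen, gives a 1.1-fold higher number from compound 2 to compound 3 (0.03 log units; within the scatter), so within the nitrile series the clearance reading does not separate these two groups at this position. Going by these compounds alone, this is the first measured exchange at this position, and its step stays within the scatter, whereas the only earlier step, a 2.8-fold higher number from compound 1 to compound 2 (0.44 log units; beyond the scatter), concerns cyano in place of bromo and lies beyond it; in this small set, only the change of bromo to cyano moves the number beyond the scatter. No measurement available here explains why the two groups give matching clearance.

Going by these compounds, whether this holds for other groups at the same position remains open: a cyclic amine such as morpholine, a longer alkoxy chain or a carboxylic acid could each leave the number within the scatter or move it beyond. It is equally open whether dimethylamino at this position would give a matching result with bromo in place of the nitrile, since the pair shown here carries the nitrile on both sides.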